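Tertiary branching on the imine carbon of a cyanoguanidine series

The compounds below may be only part of what the source reports. "The series", "measured", "known", "first", "only" and "open" are said of these compounds alone.

Measured so far:
compound 1 `CC(C)CC/N=C(\NC#N)Nc1cccnc1` — 20 mg/kg
compound 2 `CC(C)/N=C(\NC#N)Nc1cccnc1` — 2.5 mg/kg
compound 3 `CCC(CC)/N=C(\NC#N)Nc1cccnc1` — 20 mg/kg

In a functional assay on the whole organism (blood, strain Wistar-Okamoto) with Rattus norvegicus as the target, with a stated time of 5 days (on this read-out higher numbers stand for an effect only at larger amounts of compound and lower numbers for an effect already at smaller amounts), compound 3 gives 20 mg/kg, level with compound 1 and together with it the highest of the three numbers; compound 2 stands furthest away, an 8.0-fold higher number from compound 2 to compound 3 (0.90 log units; beyond the scatter).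

Compound 4 `CCC(C)(CC)/N=C(\NC#N)Nc1cccnc1` is not yet measured. It differs from compound 3 by methyl in place of hydrogen on a saturated chain carbon bound to a double-bonded nitrogen and two saturated chain carbons; cut one bond further out, the change reads pentan-3-yl to 1-ethyl-1-methylpropyl.

Among the measured compounds shown here, the steps that bear on it all alter the group on the double-bonded nitrogen: an 8.0-fold lower number from compound 1 to compound 2 (0.90 log units; beyond the scatter); an 8.0-fold higher number from compound 2 to compound 3 (0.90 log units; beyond the scatter); no change at the digits printed from compound 1 to compound 3 (within the scatter). Growing the group from isopropyl to pentan-3-yl raised the number, while isopentyl and pentan-3-yl do not separate. For the measured compounds named here, a further methyl on the same carbon is therefore expected to leave the number where it is or push it somewhat higher, a step of a 2.0-fold higher number from compound 3 to compound 4 (0.30 log units; within the scatter), with the one-pentan-3-yl precedent the only direct guide.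

Compound 4 is estimated at 40 mg/kg, within 15 mg/kg to 120 mg/kg.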

Compound 4, minimum effective dose: 0.5 mg/kg
Compound 4: middle estimate off by 80-fold (1.90 log units), on the high side; measured number below the stated range.
By their numbers in this assay, from the lowest: compound 4; then compound 2; then compounds 1 and 3 (each within the scatter of the next).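

In this assay, methyl in place of hydrogen on the saturated chain carbon bound to the double-bonded nitrogen and two saturated chain carbons gives (a 40-fold lower number from compound 3 to compound 4 (1.60 log units; beyond the scatter)), so this position responds strongly to a change far smaller than the one that left isopentyl and pentan-3-yl unseparated. The 1-ethyl-1-methylpropyl group also gives (a 5.0-fold lower number from compound 2 to compound 4 (0.70 log units; beyond the scatter)) against isopropyl and (a 40-fold lower number from compound 1 to compound 4 (1.60 log units; beyond the scatter)) against isopentyl, which leaves compound 4 with the lowest number of the four. Adding carbon to this group therefore does not move the number in one direction: compound 3 goes up from compound 2, while compound 4 comes down from both.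

No measurement shown accounts for this step. From the compounds shown here alone, whether the low number requires both ethyl arms or also appears with tert-butyl or 1-methylcyclohexyl on the same nitrogen remains open.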